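Bromo for Methyl on a Shared Indole-Bearing Core

The source may report more compounds than this note shows. Statements on the series, on what has been measured and on what is new or still open speak of the compounds shown alone.

Compound 1, `COC(=O)[C@@]1(C)CCC=C2[C@@H]1CC[C@@H](C)[C@]2(C)Cc1c[nH]c2ccc(C)cc12`, gives 15000 nM in a functional assay on SW1573 cells (Homo sapiens) for inhibition, read by sulforhodamine B assay, with a stated time of 48 h; on this read-out higher numbers stand for weaker inhibition of growth and lower numbers for stronger inhibition of growth.
Compound 2, `COC(=O)[C@@]1(C)CCC=C2[C@@H]1CC[C@@H](C)[C@]2(C)Cc1c[nH]c2ccc(Br)cc12`, gives 12000 nM in this assay.
Compound 3, `COC(=O)[C@@]1(C)CCC=C2[C@@H]1CC[C@@H](C)[C@]2(C)Cc1c(C)[nH]c2c(C)cccc12`, gives 15000 nM in this assay.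

All three measured compounds sit close together in this assay. The change from compound 1 to compound 2 is bromo in place of methyl on an aromatic carbon, and it made a 1.3-fold lower number from compound 1 to compound 2 (0.10 log units; within the scatter), so the two values cannot be told apart. Compound 3 and compound 1 share the same value at the digits given; how their cores differ is not broken down here.

Compound 4, `COC(=O)[C@@]1(C)CCC=C2[C@@H]1CC[C@@H](C)[C@]2(C)Cc1c(C)[nH]c2c(Br)cccc12`, has not been measured. It differs from compound 3 by bromo in place of methyl on an aromatic carbon. For the measured compounds named here, this is the same kind of change as the one from compound 1 to compound 2, but not the same: in compound 2 the bromo sits meta to a fused ring and para to a fused ring, while in compound 4 it sits ortho to a fused ring and meta to a fused ring.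

The expected size of the step is a 1.3-fold lower number from compound 3 to compound 4 (0.10 log units; within the scatter), because the same kind of change gave a 1.3-fold lower number from compound 1 to compound 2 (0.10 log units; within the scatter), a step that stayed within the scatter. Compound 4 is therefore expected near 12000 nM, with a likely range from 5000 nM to 30000 nM.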

Compound 4, concentration for 50% growth inhibition: 25000 nM
Compound 4: middle estimate off by 2.1-fold (0.32 log units), on the low side; the range from low to high includes it.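

In this assay, bromo in place of methyl on an aromatic carbon, ortho to a fused ring and meta to a fused ring, gave a 1.7-fold higher number from compound 3 to compound 4 (0.22 log units; within the scatter), so the two values cannot be told apart. Set beside the earlier step, the change does not give a distinguishable result on the two cores: the same change on two cores in this assay, a 1.3-fold lower number (0.10 log units; within the scatter) from compound 1 to compound 2 and a 1.7-fold higher number (0.22 log units; within the scatter) from compound 3 to compound 4, 2.1-fold (0.32 log units) apart, within the scatter of two such steps. For the compounds shown here, this shows that, in both pairs, swapping methyl for bromo left the read-out within the usual scatter, but it does not show that the change has no effect or that it would behave alike on every core, as steps this small could still hide a modest real difference, only two pairs are available, and the bromo sits at a different place in each, so core and place are not separated.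

The compounds shown leave open whether a different kind of group on this aromatic carbon, such as an amine, a carboxylic acid or a longer chain, would move the number beyond the scatter. They also leave open whether replacing the methyl ester on the shared core with a carboxylic acid or an amide would do so.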